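Aryloxy ring swap in an indole series: pyridinyl to thiazolyl

A few compounds are considered here, and "the series" means these few. Any claim that something is new, unique, unknown or untested is made for them only; others in the source may bear on it.

Measured compounds:
compound 1, `CC(C)(/C=N/OCC(=O)O)Cc1c(SC(C)(C)C)c2cc(OCc3cccc(Cl)n3)ccc2n1Cc1ccc(Cl)cc1`, 2.6 umol/kg
compound 2, `CC(C)c1ccc2c(c1)c(SC(C)(C)C)c(CC(C)(C)CN(O)C(N)=O)n2Cc1ccc(Cl)cc1`, 46 umol/kg
compound 3, `CC(C)(C)Sc1c(CC(C)(C)C(=O)O)n(Cc2ccc(Cl)cc2)c2ccc(OCc3cccc(Cl)n3)cc12`, 1.2 umol/kg

In a functional assay on the whole organism (Peritoneal cavity) with Rattus norvegicus as the target (on this read-out lower numbers stand for an effect already at smaller amounts and higher numbers for an effect only at larger amounts of compound), compound 1 stands second highest of the three numbers, nearest to compound 3 and furthest from compound 2. Going by the values given here, the one single-point step, a 2.2-fold lower number from compound 1 to compound 3 (0.34 log units; beyond the scatter), concerns the chain end and not the aryloxy ring; compound 2 differs from compound 1 in several places at once, so only its value and that of compound 1 can be set side by side. Compound 4, `CC(C)(/C=N/OCC(=O)O)Cc1c(SC(C)(C)C)c2cc(OCc3cscn3)ccc2n1Cc1ccc(Cl)cc1`, carries 1,3-thiazol-4-yl in place of 6-chloropyridin-2-yl on a saturated chain carbon bound to an oxygen on an aromatic ring. Among the compounds with values here, no measured step touches this position, so no direction is indicated and the expectation is a change within the scatter. Compound 4 is therefore expected at 3.5 umol/kg in this assay, range 1.2 umol/kg to 10 umol/kg, a step of a 1.3-fold higher number from compound 1 to compound 4 (0.13 log units; within the scatter).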

Compound 4, dose for half-maximal effect: 4.4 umol/kg
Compound 4: middle estimate off by 1.3-fold (0.10 log units), on the low side, and the stated range covers the measured number.
By their numbers in this assay, from the lowest: compound 3; then compounds 1 and 4 (each within the scatter of the next); then compound 2.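

In this assay, going by these compounds alone, the swap to 1,3-thiazol-4-yl from 6-chloropyridin-2-yl, on a saturated chain carbon bound to an oxygen on an aromatic ring, gives a 1.7-fold higher number from compound 1 to compound 4 (0.23 log units; within the scatter) and so offers the first reading at this position. With the chain end of compound 1, a five-membered aromatic ring without chlorine therefore holds the number as well as the chlorinated six-membered ring. Nothing available explains this outcome. Still open, going by these compounds, is whether the swap reads the same with the carboxylic acid chain end of compound 3, and whether an unsubstituted pyridin-2-yl or a phenyl ring would fit here.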